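A few compounds are considered here, and "the series" means these few. Any claim that something is new, unique, unknown or untested is made for them only; others in the source may bear on it.

In a functional assay on ECa-109 cells (Homo sapiens) for cytotoxicity, read by MTT assay, with a stated time of 48 h (on this read-out lower numbers stand for stronger inhibition and higher numbers for weaker inhibition), compound 3, `COc1ccc(-c2c(-c3cc(OC)c(OC)c(OC)c3)noc2N(C(C)=O)C(C)=O)cc1OC`, reads > 50000 nM, which is a limit and not a number. Compound 1, `COc1cc(-c2noc(N)c2-c2ccc(Cl)cc2)cc(OC)c1OC`, gives > 50000 nM, also a limit. Compound 2, `COc1ccc(-c2c(-c3cc(OC)c(OC)c(OC)c3)noc2N(C(C)=O)C(C)=O)cc1`, gives 390 nM. Among the compounds with values here, the one measured step, an at least 120-fold higher number from compound 2 to compound 3 (2.10 log units; beyond the scatter), is large and comes from methoxy in place of hydrogen on an aromatic carbon. Compound 4, `COc1cc(-c2noc(N(C(C)=O)C(C)=O)c2-c2ccc(Cl)cc2)cc(OC)c1OC`, differs from compound 3 by 4-chlorophenyl in place of 3,4-dimethoxyphenyl on an aromatic carbon. This change removes the 3,4-dimethoxyphenyl group, so the step to compound 3 from compound 2 suggests a large move to a lower number in this assay. The expected step is an at least 25-fold lower number from compound 3 to compound 4 (1.39 log units; beyond the scatter). For compound 4 the estimated value is 2000 nM, with an expected range of 200 nM to 30000 nM.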

Compound 4, half-maximal inhibitory concentration: 39800 nM
For compound 4 the middle estimate is 20-fold (1.30 log units) below the measured one, outside the stated range (above it).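

In this assay, chloro in place of methoxy on an aromatic carbon gives a large step: a 100-fold higher number from compound 2 to compound 4 (2.01 log units; beyond the scatter). An added methoxy and a swap to chloro, two different changes to the 4-methoxyphenyl group of compound 2, both give large moves to higher numbers. The two other new steps are an at least 1.2-fold lower number from compound 3 to compound 4 (0.09 log units; that floor lies within the scatter) and an at least 1.2-fold lower number from compound 1 to compound 4 (0.09 log units; that floor lies within the scatter). These two steps give only a floor and no exact size because those values are limits: the limit of > 50000 nM in this assay, at which 2 of the 4 values shown sit. Still open, as far as these compounds go, is whether fluoro, hydroxyl or dimethylamino in place of that methoxy would keep a number close to that of compound 2.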